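Amine Chain Variants and Microsomal Clearance

The compounds below may be only part of what the source reports. "The series", "measured", "known", "first", "only" and "open" are said of these compounds alone.

Compound 1 `N[C@H]1CC[C@@H](Oc2ccc([C@H]3CC[C@]4(CC3)OOC3(O4)C4CC5CC(C4)CC3C5)cc2)CC1`: in an ADME assay on microsomes from liver (Homo sapiens) for metabolic stability, read by LC-MS, tested at 1 uM (a lower number here means slower removal, a higher number faster removal of the compound), compound 1 gives < 7 mL.min-1.g-1, a limit of the assay.
Compound 2 `NCCCOc1ccc([C@H]2CC[C@]3(CC2)OOC2(O3)C3CC4CC(C3)CC2C4)cc1`: in this assay compound 2 gives < 7 mL.min-1.g-1, also a limit.
Compound 3 `NCCOCCOc1ccc([C@H]2CC[C@]3(CC2)OOC2(O3)C3CC4CC(C3)CC2C4)cc1`: in this assay compound 3 gives < 7 mL.min-1.g-1, again a limit.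

Compound 3 thus stands where every measured value sits, namely at the limit of < 7 mL.min-1.g-1 in this assay, at which 3 of the 3 values shown sit. Compound 4 `NCCCCCOc1ccc([C@H]2CC[C@]3(CC2)OOC2(O3)C3CC4CC(C3)CC2C4)cc1` differs from compound 3 by 3-aminopropyl in place of 2-aminoethoxy on a saturated chain carbon, two bonds along the chain from an oxygen on an aromatic ring. Among the compounds with values here, the steps that bear on this change are a step that the two limits leave unreadable from compound 1 to compound 3 and a step that the two limits leave unreadable from compound 2 to compound 3, with a step that the two limits leave unreadable from compound 1 to compound 2 alongside; none of them has a readable size. No step beyond the scatter is therefore expected in this assay on going to compound 4. Compound 4 is expected to give 5 mL.min-1.g-1 in this assay, between 2 mL.min-1.g-1 and 12 mL.min-1.g-1, which means an estimated step that the limit leaves unreadable from compound 3 to compound 4.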

Compound 4, intrinsic clearance in microsomes: < 7 mL.min-1.g-1
Compound 4: no number, only a limit (the forecaster's own chance of this, stated with the estimate: 70%); the middle value is on the limit's open side.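

The result for compound 4 is a limit, so its steps from compound 1, compound 2 and compound 3 cannot be read: the limit of < 7 mL.min-1.g-1 in this assay, at which 4 of the 4 values shown sit.

The compounds shown leave open whether these amine chains differ from one another at all in this assay.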